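Moving from 3-fluorobenzyl to 4-fluorobenzyl on a shared core

The compounds below may be only part of what the source reports. "The series", "measured", "known", "first", "only" and "open" are said of these compounds alone.

In a functional assay on G-361 cells (Homo sapiens) for antiproliferative activity, with a stated time of 72 h (on this read-out lower numbers stand for stronger inhibition and higher numbers for weaker inhibition), compound 1 `OC[C@H]1O[C@@H](n2cnc3c(NCc4ccccc4F)ncnc32)[C@H](O)[C@@H]1O` carries the entry "not determined" (no result reported), so it offers no comparison. Compound 2 `OC[C@H]1O[C@@H](n2cnc3c(NCc4cccc(F)c4)ncnc32)[C@H](O)[C@@H]1O` gives > 166000 nM in this assay, and that value is a limit of the assay, not a number. Compound 2 therefore stands at a limit, and the series holds no measured number yet.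

Compound 3 `OC[C@H]1O[C@@H](n2cnc3c(NCc4ccc(F)cc4)ncnc32)[C@H](O)[C@@H]1O` has 4-fluorophenyl in place of 3-fluorophenyl on a saturated chain carbon bound to a nitrogen on an aromatic ring. Among the compounds with values here, no measured step gives a size for such a change, so no shift beyond the scatter is expected in this assay. The estimated step of an at least 1.3-fold lower number from compound 2 to compound 3 (0.14 log units; that floor lies within the scatter) is correspondingly small, and a second limit is a likely outcome. For compound 3 the expected value is 120000 nM, with an estimated range of 15000 nM to 250000 nM.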

Compound 3, half-maximal inhibitory concentration: > 166000 nM
Compound 3: a limit, no number; the forecaster's own chance of this, stated with the estimate: 60%; middle value at least 1.3-fold (0.14 log units) from the limit.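

Compound 2 and compound 3 both stand at a limit rather than a number, so no step between them can be read: the limit of > 166000 nM in this assay, at which 2 of the 3 values shown sit.

Still open, from the compounds shown here alone, is whether 4-fluorobenzyl in place of 3-fluorobenzyl changes the result in this assay at all, and in which direction.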